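The source may hold more compounds than are shown below. What is called first, only, known or untested is meant among the compounds shown, and "the series" means these compounds.

Among the compounds with values here, compound 1 `Cc1nc(CO)ccc1-c1cnc(NCc2c(F)ccc3c2CCO3)c2cn[nH]c(=O)c12` is the one compound here with a plain number in an ADME assay on microsomes from liver (Homo sapiens) for metabolic stability, read by LC-MS, using NADPH, with stated times of 5 min and 30 min, tested at 1 uM; a lower number here means slower removal, a higher number faster removal of the compound: in this assay compound 1 gives 11 mL.min-1.g-1. Compound 2 `C[C@H]1CC(=O)N(c2cnc(NCc3c(F)ccc4c3CCO4)n3cnnc23)C1` was run in the same assay, but for compound 2 the read-out is a limit rather than a number, < 3 mL.min-1.g-1, so its value is known only as sitting at the limit of < 3 mL.min-1.g-1 in this assay, at which 1 of the 2 values shown sits. Within the data shown here, the two cannot be set side by side as an ordered pair, and no change between two measured compounds is given, so the pair shows only that compound 1 has a number and compound 2 a limit.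

Compound 3 `CNC(=O)c1ncc(-c2cnc(NCc3c(F)ccc4c3CCO4)c3cn[nH]c(=O)c23)n1C` has not yet been measured. It differs from compound 1 at one place, (1-methyl-2-(methylcarbamoyl)-1H-imidazol-5-yl in place of 6-(hydroxymethyl)-2-methylpyridin-3-yl on an aromatic carbon), and the rest of the shared core is unchanged. Among the measured compounds shown here, with no measured step to lean on, the change from compound 1 to compound 3 is expected to move the clearance by little, and the step of a 1.2-fold lower number from compound 1 to compound 3 (0.09 log units; within the scatter) is estimated to lie within the usual scatter of this assay. Compound 3 is therefore expected to give about 9 mL.min-1.g-1 in this assay, with a likely range from 3 mL.min-1.g-1 to 25 mL.min-1.g-1.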

Compound 3, intrinsic clearance in microsomes: 24 mL.min-1.g-1
Compound 3: middle estimate off by 2.7-fold (0.43 log units), on the low side; low and high end bracket the measured number.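

In this assay, within the data shown here, placing 1-methyl-2-(methylcarbamoyl)-1H-imidazol-5-yl in place of 6-(hydroxymethyl)-2-methylpyridin-3-yl gives a 2.2-fold higher number from compound 1 to compound 3 (0.34 log units; beyond the scatter), the only step here that can be read as a change at a single place. It shows that this aromatic carbon, two atoms from the ring nitrogen, is not a silent position: with the rest of the shared core unchanged, the group placed there can move the clearance by more than repeat measurements would, though only modestly. The change swaps a six-membered aromatic ring for a five-membered one and also alters the hetero atoms and the side chains on the ring, and no measurement shown ties the step to any one of these features.

As far as these compounds go, it remains open which part of the entering group carries the step, and a plain phenyl group or an imidazole ring bearing a nitrile in place of the methylcarbamoyl at this position would help separate the ring from its side chain. From the compounds shown here alone, it also remains open whether the same swap would give a similar step on a different core.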